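The compounds below may be only part of what the source reports. "The series", "measured", "known", "first", "only" and "open" are said of these compounds alone.

Measured so far:
compound 1 `CN(C)c1ccc(C2C(C#N)=C(N)OC(c3c[nH]c4ccccc34)=C2C#N)cc1`: 14.4%
compound 2 `COc1ccc(C2C(C#N)=C(N)OC(c3c[nH]c4ccccc34)=C2C#N)cc1`: 12.4%

In a functional assay, tested at 50 ug/mL (on this read-out lower numbers stand for a weaker effect and higher numbers for a stronger effect at the one concentration tested), compound 2 gives 12.4%, the lowest of the two numbers, though compound 1 at 14.4% lies within the scatter of it, as a number 2 percentage points lower from compound 1 to compound 2 (within the scatter) shows. Compound 3 `N#CC1=C(N)OC(c2c[nH]c3ccccc23)=C(C#N)C1c1ccccc1` differs from compound 2 by hydrogen in place of methoxy on an aromatic carbon. For the measured compounds named here, the one measured step, a number 2 percentage points lower from compound 1 to compound 2 (within the scatter), exchanged one group for another on an aromatic carbon and stayed within the scatter; no measured step removes a group outright, so the data give little guidance on the size of this change. Compound 3 is therefore expected to give about 12%, with a range from 3% to 24%, an estimated step of a number 0.4 percentage points lower from compound 2 to compound 3 (within the scatter) that stays within the scatter.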

Compound 3, a percentage reported as activity, at one concentration (the size of the read-out at that concentration, not a potency): 14.4%
Compound 3: middle estimate off by 2.4 percentage points, on the low side, and the stated range covers the measured number.
By their numbers in this assay, from the lowest: compounds 2, 1 and 3 (each within the scatter of the next).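

With the methoxy group gone, this assay gives a number 2 percentage points higher from compound 2 to compound 3 (within the scatter) and, against the dimethylamino compound, no change at the digits printed from compound 1 to compound 3 (within the scatter) as well. Unlike the earlier exchange of one group for another, this shows that plain hydrogen on this aromatic carbon, para to a large group, cannot be told apart from either substituent at the one concentration tested. No available evidence bears on this result. From the compounds shown here alone, what remains open is whether any other group here, such as a carboxylic acid, chlorine or a longer chain, would move the number beyond the scatter.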